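Methylene lactone carbamates: aryl substituent swap at the carbamate

The source may hold more compounds than are shown below. What is called first, only, known or untested is meant among the compounds shown, and "the series" means these compounds.

Of the compounds shown here, two have numbers so far. Compound 1 `C=C1C(=O)OC[C@H]1CCOC(=O)Nc1ccc(OC)cc1` carries a methoxy on the aryl carbamate; compound 2 `C=C1C(=O)OC[C@@H]1CCOC(=O)Nc1ccc(Br)cc1` carries a bromo. In a functional assay on RAW264.7 cells (Mus musculus) for inhibition, with a stated time of 30 min (on this read-out higher numbers stand for weaker inhibition and lower numbers for stronger inhibition), compound 1 gives 710 nM, and in this assay compound 2 gives 720 nM. Compound 2 holds the higher of the two numbers, but the gap to compound 1 lies within the scatter, so the two read as equivalent on this read-out.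

Compound 3 `C=C1C(=O)OC[C@@H]1CCOC(=O)Nc1ccc(OC)cc1` is the next compound to be run. It differs from compound 2 by one change on the aryl carbamate: methoxy in place of bromo on an aromatic carbon. Within the data shown here, no measured pair isolates this change, so the expectation rests on what the two measured compounds show. Because compound 1 with its methoxy gives 710 nM and compound 2 with its bromo gives 720 nM, the swap is expected to produce no step beyond the scatter, in either direction, which is what a 1.0-fold lower number from compound 2 to compound 3 (0.01 log units; within the scatter) means here. Compound 3 is therefore estimated at 700 nM, with a range from 300 nM to 1600 nM.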

Compound 3, half-maximal inhibitory concentration: 1090 nM
Compound 3: the middle estimate sits 1.6-fold (0.19 log units) below what was measured; the measured number falls inside the stated range.
By their numbers in this assay, from the lowest: compounds 1, 2 and 3 (each within the scatter of the next).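

In this assay, replacing bromo with methoxy on the aromatic carbon, para to a large group, gives a 1.5-fold higher number from compound 2 to compound 3 (0.18 log units; within the scatter), so this read-out does not tell the two groups apart at this position in the configuration of compound 3. The stereocentre at the saturated ring carbon, drawn S in compound 1 and R in compound 3, gives a 1.5-fold higher number from compound 1 to compound 3 (0.19 log units; within the scatter), so the two drawn configurations of the methoxy carbamate are not separated by this read-out either. This second pair gives the series its first isolated test of configuration, and that reading rests on one structural point: the fact that compounds 1 and 3 differ only in the configuration as drawn

Both steps lie within the scatter, so neither group nor configuration has yet been shown to move the number at this end of the series, and whether configuration counts in the same way with bromo on the ring stays open. Also open, going by these compounds, is whether an amine or a carboxylic acid on that aromatic carbon, or a longer chain in place of the methoxy, would give a step beyond the scatter.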